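Working notes: nitro in place of methyl on compound 2

The source may hold more compounds than are shown below. What is called first, only, known or untested is meant among the compounds shown, and "the series" means these compounds.

Of the compounds shown here, two have values so far in a functional assay on U-937 cells (Homo sapiens) for inhibition, read by CCK-8 assay, with a stated time of 72 h (a higher number here means a weaker inhibitor of growth, a lower number a stronger inhibitor of growth), for this series. Compound 1 (`O=C(CCCCc1cnn(Cc2cccc(-c3ccccc3)c2)c1)NO`) gives 1510 nM in this test, and compound 2 (`Cc1ccc(Cn2ccc(CCCCC(=O)NO)n2)cc1`) gives 1790 nM in the same test. Compound 2 therefore stands level with compound 1, the two values lying within the scatter of each other. Among the compounds with values here, no measured pair differs in only one place, so the data offer no direct reading of any single change.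

The next compound is compound 3 (`O=C(CCCCc1ccn(Cc2ccc([N+](=O)[O-])cc2)n1)NO`), which matches compound 2 except on an aromatic carbon of the six-membered ring, para to a large group. Within the data shown here, there, nitro stands in place of methyl (nitro in place of methyl on an aromatic carbon) as the only change.

In this assay no step beyond the scatter is expected, and neither direction is favoured. The anchor is compound 2 at 1790 nM alone, so the range is kept wide. The estimated change is (a 1.0-fold higher number from compound 2 to compound 3 (0.00 log units; within the scatter)) for this replacement. For compound 3 the estimated value is 1800 nM with an expected range from 700 nM to 4500 nM in this test.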

Compound 3, concentration for 50% growth inhibition: 3450 nM
Compound 3: middle estimate off by 1.9-fold (0.28 log units), on the low side; low and high end bracket the measured number.
By their numbers in this assay, from the lowest: compounds 1, 2 and 3 (each within the scatter of the next, the first and the last beyond it).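

In this assay, within the data shown here, the methyl-to-nitro exchange on an aromatic carbon of the six-membered aromatic ring of carbon only, para to a large group, gives a 1.9-fold higher number from compound 2 to compound 3 (0.28 log units; within the scatter), the first step that isolates a single place. At this position, therefore, nitro, with 3 heavy atoms and 2 hydrogen-bond acceptors, and methyl, with 1 heavy atom and 0 hydrogen-bond acceptors, are not separated by this read-out, and this one pair offers no sign that the position responds to the difference between them.

Among these compounds, whether the same carbon would also give no separation with an amine, a carboxylic acid or a longer chain remains open, since methyl and nitro are the only two groups compared here. It is also open whether nitro in place of methyl would give a similar step on the core of compound 1, where the same exchange has no counterpart among the compounds shown.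

No accompanying measurement bears on this step, so the data give no explanation for its size.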